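This account rests on a few compounds, and the source may have more. Where it says the series, first, only, none or still open, it means among the compounds named here.

Compound 1, with the structure `O=C1O[C@H]([C@@H](O)Cn2cc(CNS(=O)(=O)c3ccc(F)cc3)nn2)C(OCc2ccccc2)=C1OCc1ccccc1`, and compound 2, with the structure `Cc1ccc(S(=O)(=O)NCc2cn(C[C@H](O)[C@H]3OC(=O)C(OCc4ccccc4)=C3OCc3ccccc3)nn2)cc1`, share a core and differ only in the group on the sulfonyl sulfur. In a functional assay on HepG2 cells (Homo sapiens) for antiproliferative activity, read by MTT assay, with a stated time of 72 h (on this read-out higher numbers stand for weaker inhibition and lower numbers for stronger inhibition), compound 1 gives 18300 nM. In the same assay compound 2 gives 24900 nM. The step of a 1.4-fold higher number from compound 1 to compound 2 (0.13 log units; within the scatter) is within the scatter, so the two compounds cannot be told apart on these numbers, and compound 2 stands with the higher of the two numbers only by a margin that repeated measurements would blur.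

Compound 3, with the structure `O=C1O[C@H]([C@@H](O)Cn2cc(CNS(=O)(=O)c3ccc(Cl)cc3F)nn2)C(OCc2ccccc2)=C1OCc1ccccc1`, is not yet measured. Its change from compound 2 is 4-chloro-2-fluorophenyl in place of 4-methylphenyl on a sulfonyl sulfur. For the measured compounds named here, the only measured step that bears on this change is the exchange of methyl for fluoro on the same ring, seen in a 1.4-fold higher number from compound 1 to compound 2 (0.13 log units; within the scatter), which lies within the scatter. The new change again swaps substituents on that ring, so no step beyond the scatter is expected in this assay, in either direction. Compound 3 is therefore estimated at 21000 nM, with a range from 8000 nM to 55000 nM, which amounts to an expected step of a 1.2-fold lower number from compound 2 to compound 3 (0.07 log units; within the scatter).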

Compound 3, half-maximal inhibitory concentration: 25500 nM
Estimate against measurement, compound 3: 1.2-fold (0.08 log units) below; measured number inside the range.
By their numbers in this assay, from the lowest: compounds 1, 2 and 3 (each within the scatter of the next).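

Compounds 1 and 2 each carry a single substituent on the aromatic ring, whereas compound 3 brings two halogens to that ring, as 4-chloro-2-fluorophenyl on a sulfonyl sulfur. In this assay, for the compounds shown here, this group in place of 4-methylphenyl gives a 1.0-fold higher number from compound 2 to compound 3 (0.01 log units; within the scatter) and in place of 4-fluorophenyl gives a 1.4-fold higher number from compound 1 to compound 3 (0.14 log units; within the scatter) so a second substituent on the ring, and a chlorine among them, yields no step that can be told from repeated measurement, and the three compounds cannot be separated on these numbers. Nothing measured alongside these numbers speaks to why the three groups read alike.

As far as these compounds go, all three compounds keep a six-membered aromatic ring of carbon on the sulfonyl sulfur, bearing only fluoro, chloro or methyl, so it stays open whether an amine or a carboxylic acid on that ring, or a plain alkyl chain in place of the ring, would give a step beyond the scatter. The shared core is also the same throughout, so these compounds say nothing about how the number responds to a change anywhere else in the molecule.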